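A few compounds are considered here, and "the series" means these few. Any claim that something is new, unique, unknown or untested is made for them only; others in the source may bear on it.

Measured so far in a functional assay for inhibition, with Homo sapiens as the target; on this read-out lower numbers stand for tighter binding and higher numbers for weaker binding:
compound 1 `O=C(O)CC/C=C\CC1COC(c2ccc3ccccc3c2)OC1c1cccnc1`, 1780 nM
compound 2 `Cc1ccc(OC(C)(C)C2OCC(C/C=C\CCC(=O)O)C(c3cccnc3)O2)cc1`, 631 nM

Compound 2 holds the lowest of the two numbers in this assay; compound 1 sits a good way higher, a gap beyond the usual scatter. Compound 3 `CC(C)(Cc1ccccc1)C1OCC(C/C=C\CCC(=O)O)C(c2cccnc2)O1` is not yet measured. It differs from compound 2 in one place: benzyl in place of 4-methylphenoxy on a saturated chain carbon bound to two saturated chain carbons and a saturated ring carbon. Among the compounds with values here, no step of this kind is among the measured pairs, so the direction is open; the expectation is a change within or just beyond the scatter, a 1.3-fold higher number from compound 2 to compound 3 (0.10 log units; within the scatter). In this assay compound 3 is therefore expected near 800 nM, in a range from 300 nM to 2200 nM.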

Compound 3, dissociation constant: 513 nM
Estimate against measurement, compound 3: 1.6-fold (0.19 log units) above; the range from low to high includes it.
By their numbers in this assay, from the lowest: compounds 3 and 2 (each within the scatter of the next); then compound 1.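

In this assay, benzyl in place of 4-methylphenoxy on a saturated chain carbon bound to two saturated chain carbons and a saturated ring carbon gives a 1.2-fold lower number from compound 2 to compound 3 (0.09 log units; within the scatter), so losing the oxygen of the leaving group leaves the read-out within the scatter. Replacing naphthalen-2-yl on a saturated ring carbon with 1-benzyl-1-methylethyl gives a 3.5-fold lower number from compound 1 to compound 3 (0.54 log units; beyond the scatter), a step beyond the scatter. Nothing measured here explains either step.

From the compounds shown here alone, how an amine or a longer chain in place of benzyl on this carbon would read remains open.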